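The compounds below may be only part of what the source reports. "The series", "measured", "known", "first", "only" and "open" are said of these compounds alone.

Working notes on the series. The core of compound 1 `Cc1n[nH]c(-c2ncc3cccnc3c2O)n1` gives 0.73 in a physicochemical assay for lipophilicity, at pH 7.4; a lower number here means a more polar compound, a higher number a more lipophilic compound. Among the compounds with values here, compound 2 `Cc1n[nH]c(-c2ncc3c(N(C)C)ccnc3c2O)n1` gives -0.6, the lowest of the three numbers so far, and compound 3 `Cc1n[nH]c(-c2ncc3c(NCc4ccc(Cl)cc4)ccnc3c2O)n1`, which carries a different nitrogen-linked group at the same place, gives 4.4.

The next compound is compound 4 `Cc1n[nH]c(-c2ncc3c(N4CCCCS4(=O)=O)ccnc3c2O)n1`. Its change from compound 2 is a group of 8 heavy atoms (4 carbon, 1 nitrogen, 2 oxygen, 1 sulfur; one six-membered non-aromatic ring with 2 hetero atoms) in place of a group of 3 heavy atoms (2 carbon, 1 nitrogen; no ring), on an aromatic carbon. A group of 8 heavy atoms with one six-membered non-aromatic ring replaces dimethylamino, on an aromatic carbon opposite the ring nitrogen.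

Within the data shown here, only one measured step bears on this directly: a number 1.33 log units lower from compound 1 to compound 2 (beyond the scatter), a large drop when dimethylamino replaced hydrogen. Among the measured compounds shown here, no measured step starts from dimethylamino and replaces it with another group, so the size of the change is inferred only loosely. The values of compound 2 and compound 3 show how widely this place can move the number. Compound 4 is expected to recover roughly what compound 2 lost against compound 1, and to stay far short of compound 3.

A large upward step is therefore expected, estimated as a number 1.10 log units higher from compound 2 to compound 4 (beyond the scatter). The estimate for compound 4 is 0.5, with an expected range of -0.2 to 1.3.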

Compound 4, distribution coefficient: 1.5
Compound 4: middle estimate off by 1.00 log units, on the low side; measured number above the stated range.
By their numbers in this assay, from the lowest: compound 2; then compound 1; then compound 4; then compound 3.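

In this assay, the step of a number 2.10 log units higher from compound 2 to compound 4 (beyond the scatter) shows that the low number of compound 2 does not extend to every group joined through nitrogen on this aromatic carbon opposite the ring nitrogen. Within the data shown here, the step of a number 0.77 log units higher from compound 1 to compound 4 (beyond the scatter) places the group of 8 heavy atoms, with its six-membered non-aromatic ring with 2 hetero atoms, above hydrogen, so compound 4 joins compound 3 on the higher side of compound 1, and compound 2 is the one compound that goes against this direction. No measurement at hand accounts for the size of either step.

The compounds shown leave open how much of the rise from compound 2 belongs to the ring and how much to the sulfur with its two oxygens, a question that a cyclic amine with only carbon beside its nitrogen, or an open-chain sulfonamide at the same place, would separate. Also open, going by these compounds, is how the number at this place follows a longer alkyl chain on the amine nitrogen, set against the dimethylamino of compound 2.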